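The source may report more compounds than this note shows. Statements on the series, on what has been measured and on what is new or still open speak of the compounds shown alone.

Working notes on the series around the shared core of compound 1 `CNC(=O)c1cc(Oc2ccc3nc(Nc4ccccc4)ncc3c2)ccn1`, with the amine on that core carrying a varied aryl group. In an ADME assay on Caco-2 cells (Homo sapiens) for permeability, in the apical to basolateral direction (a lower number here means that the compound crosses the layer more slowly, a higher number that the compound crosses the layer faster), compound 1 gives < 1 10^-6 cm/s, which is a limit of the assay and not a number. Compound 2 `CNC(=O)c1cc(Oc2ccc3nc(Nc4cccc(C(C)(C)C)c4)ccc3c2)ccn1` gives < 1 10^-6 cm/s in this assay, again a limit. Compound 3 `CNC(=O)c1cc(Oc2ccc3nc(Nc4cccc(Br)c4)ncc3c2)ccn1` gives < 1 10^-6 cm/s in this assay, also a limit. Within the data shown here, the step that the two limits leave unreadable from compound 1 to compound 3 therefore cannot be read; so far all that is known is the limit of < 1 10^-6 cm/s in this assay, at which 3 of the 3 values shown sit, and no measured step separates any two compounds.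

Compound 4 `CNC(=O)c1cc(Oc2ccc3nc(Nc4ccc(OC)cc4)ncc3c2)ccn1` differs from compound 3 by 4-methoxyphenyl in place of 3-bromophenyl on a nitrogen on an aromatic ring. Among the measured compounds shown here, no measured step bears on this change, and the only value of compound 3 is a limit, so the size of the step cannot be derived from the series. The expectation rests on the three limits alone: compound 4 is expected to sit at the same limit, so the step that the limit leaves unreadable from compound 3 to compound 4 is estimated as none beyond the scatter. For compound 4 the estimate in this assay is 0.7 10^-6 cm/s, in the range 0.2 10^-6 cm/s to 2.5 10^-6 cm/s.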

Compound 4, apparent permeability: < 1 10^-6 cm/s
Compound 4: a limit, no number (the forecaster's own chance of this, stated with the estimate: 75%); the middle value lies beyond the limit too.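

Compound 4 ends at a limit of the assay, like compound 1 and compound 3, so neither step to compound 4 can be read: the limit of < 1 10^-6 cm/s in this assay, at which 4 of the 4 values shown sit. The compounds shown leave open whether any aryl group on the amine of the shared core gives a readable number in this assay.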